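A few compounds are considered here, and "the series" means these few. Any claim that something is new, unique, unknown or untested is made for them only; others in the source may bear on it.

The study compares four compounds in a functional assay on MDA-MB-231 cells (Homo sapiens) for antiproliferative activity, read by MTT assay, with a stated time of 48 h; a lower number here means a stronger inhibitor, a higher number a weaker inhibitor. Compound 1, `N#Cc1ncn(-c2ccc(F)cc2)c1/N=C/c1ccc([N+](=O)[O-])cc1`, gives 13400 nM in this assay. Compound 2, `COc1cc(/C=N/c2c(C#N)ncn2-c2ccc(F)cc2)ccc1O`, gives 13600 nM in this assay; the difference between the two cores of compound 1 and compound 2 is not broken down here, and their two values lie within the scatter of each other. Compound 3, `N#Cc1ncn(Cc2ccc(F)cc2)c1/N=C/c1ccc([N+](=O)[O-])cc1`, gives 3440 nM in this assay. The change leading from compound 1 to compound 3 is 4-fluorobenzyl in place of 4-fluorophenyl on an aromatic nitrogen, and it made a step of a 3.9-fold lower number from compound 1 to compound 3 (0.59 log units; beyond the scatter).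

Compound 4, `COc1cc(/C=N/c2c(C#N)ncn2Cc2ccc(F)cc2)ccc1O`, has not yet been measured in this assay. It differs from compound 2 by 4-fluorobenzyl in place of 4-fluorophenyl on an aromatic nitrogen, which is the same change as the one from compound 1 to compound 3, made at the same place; among the compounds shown this change occurs twice. Because the measured pair gave a 3.9-fold lower number from compound 1 to compound 3 (0.59 log units; beyond the scatter), a step of similar size is expected on the core of compound 2, namely a 3.9-fold lower number from compound 2 to compound 4 (0.59 log units; beyond the scatter). This expectation rests on a single measured pair, and the two cores differ in more than one place, so the step is uncertain in size. Compound 4 is therefore estimated at 3500 nM in this assay, with a likely range from 1500 nM to 9000 nM.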

Compound 4, half-maximal inhibitory concentration: 16100 nM
Compound 4: middle estimate off by 4.6-fold (0.66 log units), on the low side, outside the stated range (above it).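

On the core of compound 2, 4-fluorobenzyl in place of 4-fluorophenyl on the aromatic nitrogen gave a 1.2-fold higher number from compound 2 to compound 4 (0.07 log units; within the scatter) in this assay, so on this core the change left the antiproliferative read-out within the usual scatter. For the compounds shown here, in this series, then, the step measured on one core did not carry over to the other, and the two results differ by more than repeated measurements would explain: the same change on two cores in this assay, a 3.9-fold lower number (0.59 log units; beyond the scatter) from compound 1 to compound 3 and a 1.2-fold higher number (0.07 log units; within the scatter) from compound 2 to compound 4, 4.6-fold (0.66 log units) apart, beyond the scatter of two such steps This shows that the effect of the change depends on the core it is made on, at least for these two cores, but it does not show which feature of the cores is responsible, as they differ in more than one place and each core contributes only a single pair.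

The four compounds leave open how the same change would behave on any further core, and whether either of the two results is the more typical one. They also leave open what a longer chain on the aromatic nitrogen, such as 2-(4-fluorophenyl)ethyl, would do on either core, or what an amine or a carboxylic acid would do in place of the nitro group of compound 3.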